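Two amide side-chains, one pyrazole core, and a third to predict

The source may report more compounds than this note shows. Statements on the series, on what has been measured and on what is new or still open speak of the compounds shown alone.

For the measured compounds named here, in an assay on isolated protein for inhibition of alkaline phosphatase, tissue-nonspecific isozyme (Homo sapiens) (a lower number here means a stronger inhibitor, a higher number a weaker inhibitor), compound 2 `COCCNC(=O)c1cc(-c2ccc(Cl)cc2Cl)n[nH]1` gives 46 nM, the lowest of the two numbers known so far. Going by the values given here, compound 1 `O=C(c1cc(-c2ccc(Cl)cc2Cl)n[nH]1)N1CCCCCC1`, which carries the same core, gives 1450 nM in this assay, and the one measured step is a 32-fold lower number from compound 1 to compound 2 (1.50 log units; beyond the scatter). Compound 3 `O=C(c1cc(-c2ccc(Cl)cc2Cl)n[nH]1)N(CCO)CCO` differs from compound 2 by bis(2-hydroxyethyl)amino in place of (2-methoxyethyl)amino on a carbonyl carbon. Among the compounds with values here, only the step from compound 1 to compound 2 bears on this change, and it shows the amide substituent can move the number a great deal. Compound 3 is therefore expected to give a weaker result than compound 2, by a 4.3-fold higher number from compound 2 to compound 3 (0.64 log units; beyond the scatter), with an estimated value of 200 nM in this assay, ranging from 60 nM to 700 nM.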

Compound 3, half-maximal inhibitory concentration: 47 nM
Compound 3: the middle estimate sits 4.3-fold (0.63 log units) above what was measured, outside the stated range (below it).
By their numbers in this assay, from the lowest: compounds 2 and 3 (each within the scatter of the next); then compound 1.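

In this assay, the position on the carbonyl carbon accepts the larger bis(2-hydroxyethyl)amino with no change beyond the scatter (a 1.0-fold higher number from compound 2 to compound 3 (0.01 log units; within the scatter)). The wide gap to compound 1 is therefore not unique to (2-methoxyethyl)amino, as a second open chain also stands far from azepan-1-yl (a 31-fold lower number from compound 1 to compound 3 (1.49 log units; beyond the scatter)). No measurement shown explains this result. Going by these compounds, it remains open whether the ring of azepan-1-yl or the absence of oxygen in that group sets compound 1 apart. A morpholine ring, which holds an oxygen inside a ring, would separate these two possibilities.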